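This account rests on a few compounds, and the source may have more. Where it says the series, first, only, none or still open, it means among the compounds named here.

Measured so far in an assay on microsomes for inhibition of acyl-CoA:cholesterol acyltransferase (Oryctolagus cuniculus); a higher number here means a weaker inhibitor, a lower number a stronger inhibitor:
compound 1 `CC(C)c1cccc(C(C)C)c1NC(=O)NCC1(c2ccc(CC(C)(C)C)cc2)CCCC1` gives 159 nM
compound 2 `CC(C)c1cccc(C(C)C)c1NC(=O)NCC1(c2ccc(F)cc2)CCCC1` gives 23 nM
compound 3 `COc1cccc(C2(CNC(=O)Nc3c(C(C)C)cccc3C(C)C)CCCC2)c1` gives 13 nM

Compound 3 holds the lowest number of the three in this assay. Its gap to compound 2 lies within the scatter, so no order between those two is claimed, whereas compound 1 stands clearly apart from both. The steps within the measured set read: a 6.9-fold lower number from compound 1 to compound 2 (0.84 log units; beyond the scatter), a 12-fold lower number from compound 1 to compound 3 (1.09 log units; beyond the scatter), and a 1.8-fold lower number from compound 2 to compound 3 (0.25 log units; within the scatter). Taken together they show that exchanging the 4-neopentylphenyl group for a smaller substituted phenyl lowers the number markedly, while fluoro and methoxy on that phenyl give numbers that cannot be told apart.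

Compound 4 `CC(C)c1cccc(C(C)C)c1NC(=O)NCC1(c2cccc(N)c2)CCCC1` differs from compound 3 by amino in place of methoxy on an aromatic carbon. Among the measured compounds shown here, no measured step exchanges one small group for another at this position. The nearest bearing is the step from compound 2 to compound 3, which stayed within the scatter; the two steps starting from compound 1 concern a much larger group and do not carry over. The expectation is therefore a small step at most in this assay, with no direction called beyond the scatter, and a 1.5-fold higher number from compound 3 to compound 4 (0.19 log units; within the scatter) is the estimated step. Compound 4 is accordingly expected near 20 nM, in the range 7 nM to 60 nM.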

Compound 4, half-maximal inhibitory concentration: 21 nM
Beside the measured number, compound 4's estimate is 1.1-fold (0.02 log units) below it; measured number inside the range.
By their numbers in this assay, from the lowest: compounds 3, 4 and 2 (each within the scatter of the next); then compound 1.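

In this assay, amino in place of methoxy on an aromatic carbon, meta to a large group, gives a 1.6-fold higher number from compound 3 to compound 4 (0.21 log units; within the scatter) so this place accepts a swap of one small group for another, one that adds a hydrogen-bond donor, with no readable shift in the number. Among the compounds shown here, the 3-aminophenyl group also stands level with the 4-fluorophenyl group at a 1.1-fold lower number from compound 2 to compound 4 (0.04 log units; within the scatter) and the gap to the 4-neopentylphenyl group stays at a 7.6-fold lower number from compound 1 to compound 4 (0.88 log units; beyond the scatter) which makes compounds 2, 3 and 4 one group of three small substituted phenyls, with compound 1 as the one compound going against it. No measurement shown here accounts for why methoxy and amino read alike.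

On these data alone, whether this flat reading holds for a carboxylic acid, a dimethylamino group or a longer chain on the same aromatic carbon stays open. A hydroxy or acetamide group in that place would show whether the level reading extends to other small groups carrying a hydrogen-bond donor, which the compounds shown cannot tell.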